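This account rests on a few compounds, and the source may have more. Where it says the series, first, only, none or still open, it means among the compounds named here.

Measured in a functional assay on HeLa cells (Homo sapiens) for inhibition, read by MTT assay, with a stated time of 72 h; on this read-out higher numbers stand for weaker inhibition and lower numbers for stronger inhibition:

- compound 1, `CN(C(=O)NC(=O)c1ccc(Cl)cc1Cl)c1nc(C(F)(F)F)c(C(=O)N/N=C/c2ccc(C(F)(F)F)cc2)s1`, gives 7.99 ug/mL
- compound 2, `CN(C(=O)NC(=O)c1cccc(C(F)(F)F)c1)c1nc(C(F)(F)F)c(C(=O)N/N=C/c2ccc(C(F)(F)F)cc2)s1`, gives 7.35 ug/mL
- compound 3, `CN(C(=O)NC(=O)c1ccc(Cl)cc1Cl)c1nc(C(F)(F)F)c(C(=O)N/N=C/c2cc(C(F)(F)F)cc(C(F)(F)F)c2)s1`, gives only a limit of the assay, > 100 ug/mL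

Compound 1 and compound 2 share a core and differ by 3-(trifluoromethyl)phenyl in place of 2,4-dichlorophenyl on a carbonyl carbon. This change produced a 1.1-fold lower number from compound 1 to compound 2 (0.04 log units; within the scatter), so the two values are read as equivalent. Compound 3 carries a different hydrazone part from compound 1; the difference between the two cores is not broken down here. For compound 3 only a limit is known, and it sits at the limit of > 100 ug/mL in this assay, at which 1 of the 3 values shown sits.

Compound 4, `CN(C(=O)NC(=O)c1cccc(C(F)(F)F)c1)c1nc(C(F)(F)F)c(C(=O)N/N=C/c2cc(C(F)(F)F)cc(C(F)(F)F)c2)s1`, remains to be measured in this assay. It stands to compound 3 as compound 2 stands to compound 1, differing by 3-(trifluoromethyl)phenyl in place of 2,4-dichlorophenyl on a carbonyl carbon. The place of the change is the same in both pairs: on a carbonyl carbon whose other neighbours are amide-type nitrogen.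

For compound 4 the step from compound 3 is expected to be a number no higher from compound 3 to compound 4 (the limit leaves the size open), which rests on the small size of a 1.1-fold lower number from compound 1 to compound 2 (0.04 log units; within the scatter) in the matched pair and on compound 3 sitting at the limit of > 100 ug/mL in this assay, at which 1 of the 3 values shown sits. Compound 4 is therefore estimated at 100 ug/mL in this assay, within a range from 40 ug/mL to 300 ug/mL, and it is expected that the assay will most likely again report only a limit rather than a number.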

Compound 4, half-maximal inhibitory concentration: 5.34 ug/mL
For compound 4 the middle estimate is 19-fold (1.27 log units) above the measured one, and the stated range ends above it.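

In this assay, 3-(trifluoromethyl)phenyl in place of 2,4-dichlorophenyl on a carbonyl carbon gives an at least 18-fold lower number from compound 3 to compound 4 (1.27 log units; beyond the scatter), while on the other hydrazone part the same change gives a 1.1-fold lower number from compound 1 to compound 2 (0.04 log units; within the scatter). The change therefore does not carry over from one core to the other with the same size, so a step read on one core cannot be transferred to the other in this series: the same change on two cores in this assay, a 1.1-fold lower number (0.04 log units; within the scatter) from compound 1 to compound 2 and an at least 18-fold lower number (1.27 log units; beyond the scatter) from compound 3 to compound 4, at least 17-fold (1.23 log units) apart, beyond the scatter of two such steps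

Compound 3 stands at a limit of the assay, > 100 ug/mL, so the step gives only a bound and its full size is unknown, and the two pairs show neither a reason for the gap nor a rule for any further core.

Still open, going by these compounds, is whether the same change on a third hydrazone part would follow the step within the scatter or the large one, and whether 2,4-dichlorophenyl or the hydrazone part of compound 3 is what the large step depends on. Also open, on these data alone, is how a carboxylic acid, an amine or a longer alkyl chain in place of these aryl groups on the carbonyl carbon would read in this assay on either core.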